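A few compounds are considered here, and "the series" means these few. Any claim that something is new, unique, unknown or untested is made for them only; others in the source may bear on it.

Measured in a functional assay on HCT-116 cells (Homo sapiens) for inhibition, read by MTT assay, with a stated time of 72 h; a lower number here means a stronger inhibitor of growth, a higher number a weaker inhibitor of growth:
- Compound 1 `CNC(=O)CCc1ccncc1-c1ccc2ccccc2c1`: 19300 nM
- Compound 2 `O=C(/C=C/c1ccncc1-c1ccc2ccccc2c1)N1CCOCC1`: 6040 nM
- Compound 3 `O=C(O)CCc1ccncc1-c1ccc2ccccc2c1`: > 30000 nM

The entry for compound 3 is a limit, not a number, and it stands at the limit of > 30000 nM in this assay, at which 1 of the 3 values shown sits. Compound 4 `O=C(/C=C/c1ccncc1-c1ccc2ccccc2c1)NC1CC1` has 2-(cyclopropylcarbamoyl)ethenyl in place of 2-carboxyethyl on an aromatic carbon. Within the data shown here, the one measured step bearing on this chain is an at least 1.5-fold higher number from compound 1 to compound 3 (0.19 log units; that floor lies within the scatter), and its floor lies within the scatter. Compound 4 is an amide, as are compound 1 and compound 2. The closer guide is compound 2, which also has an ethenyl chain and gives 6040 nM. The expected step is an at least 4.2-fold lower number from compound 3 to compound 4 (0.63 log units; beyond the scatter), towards a lower number. For compound 4 the estimate is 7000 nM, with an expected range of 2500 nM to 20000 nM.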

Compound 4, concentration for 50% growth inhibition: 6180 nM
Compound 4: the middle estimate sits 1.1-fold (0.05 log units) above what was measured, within the range that was stated.
By their numbers in this assay, from the lowest: compounds 2 and 4 (each within the scatter of the next); then compound 1. At a limit, above all of these: compound 3.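

In this assay the entry for compound 3 is only a limit: the limit of > 30000 nM in this assay, at which 1 of the 4 values shown sits. Placing 2-(cyclopropylcarbamoyl)ethenyl on this aromatic carbon instead of 2-carboxyethyl gives a step beyond the scatter, an at least 4.8-fold lower number from compound 3 to compound 4 (0.68 log units; beyond the scatter), and replacing 2-(methylcarbamoyl)ethyl with the same chain gives a 3.1-fold lower number from compound 1 to compound 4 (0.49 log units; beyond the scatter). On the carbonyl carbon of the ethenyl chain, cyclopropylamino in place of morpholin-4-yl leaves the value within the scatter, a 1.0-fold higher number from compound 2 to compound 4 (0.01 log units; within the scatter).

As far as these compounds go, it remains open how much of the step from the 2-(methylcarbamoyl)ethyl chain belongs to the ethenyl link and how much to the cyclopropylamino group. Also open, from the compounds shown here alone, is how a longer chain or an ethenyl carboxylic acid would behave at this position.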